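The source may report more compounds than this note shows. Statements on the series, on what has been measured and on what is new or still open speak of the compounds shown alone.

Working notes on the series.

Of the compounds shown here, three have been tested in a functional assay on MGC-803 cells (Homo sapiens) for antiproliferative activity, read by MTT assay, with a stated time of 72 h; a lower number here means a stronger inhibitor, a higher number a weaker inhibitor. Compound 1 `COc1ccc(-c2nc(CNc3ccc(C(=O)NO)cc3)n(-c3ccccc3)n2)cc1` reaches only a limit in this assay, > 20000 nM. Compound 3 `Cc1ccc(-c2nc(CNc3ccc(C(=O)NO)cc3)n(-c3ccccc3)n2)cc1` likewise returns only a limit in this assay, > 20000 nM. Within the data shown here, the one measured step, a step that the two limits leave unreadable from compound 1 to compound 3, is therefore unreadable in size. Among the measured compounds shown here, compound 2 `O=C(NO)c1ccc(NCc2nc(-c3ccccc3)nn2-c2ccccc2Cl)cc1` is the only member with a number: in this assay compound 2 gives 9630 nM, and that value stands alone among the three.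

Compound 4 `Cc1cccc(-n2nc(-c3ccccc3)nc2CNc2ccc(C(=O)NO)cc2)c1` is not yet measured. Its difference from compound 2: 3-methylphenyl in place of 2-chlorophenyl on an aromatic nitrogen. For the measured compounds named here, no measured step touches this position; the one step on record sits on the phenyl attached to the ring carbon and is unreadable. What can be said is the limit of > 20000 nM in this assay, at which 2 of the 3 values shown sit, so most of the series has shown no number at all. Going by the values given here, with no step bearing on the change, the expectation for compound 4 rests on compound 2 alone, allowing for a shift toward the limit in this assay; the step of a 1.6-fold higher number from compound 2 to compound 4 (0.19 log units; within the scatter) is expected to be modest and toward weaker inhibition. Compound 4 is estimated at 15000 nM in this assay, within 6000 nM to 40000 nM.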

Compound 4, half-maximal inhibitory concentration: 13200 nM
Compound 4: middle estimate off by 1.1-fold (0.06 log units), on the high side; measured number inside the range.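

In this assay, among these compounds, the change on the aromatic nitrogen gives the first readable step, a 1.4-fold higher number from compound 2 to compound 4 (0.14 log units; within the scatter). Replacing 2-chlorophenyl with 3-methylphenyl keeps the count of heavy atoms and the aromatic ring of carbon only, and this pair shows no separation between the two groups beyond the scatter. Compound 4 also adds a second number to a series that had only one, so numbers and limits are now equal in count: the limit of > 20000 nM in this assay, at which 2 of the 4 values shown sit.

The step changes both the substituent and where it sits on the phenyl, so the contribution of each cannot be read apart from this single pair. As far as these compounds go, whether a larger change on this nitrogen, such as a benzyl group, a pyridyl ring or a phenyl carrying an amine, would move the number beyond the scatter remains open.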